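The source may hold more compounds than are shown below. What is called first, only, known or untested is meant among the compounds shown, and "the series" means these compounds.

Measured so far:
compound 1, `N=C(N)c1ccc2cc(-c3cccc(OCCCOc4ccccc4)c3)oc2c1` — 19800 nM
compound 2, `N=C(N)c1ccc2cc(-c3cccc(OCCCCOc4ccccc4)c3)oc2c1` — 7600 nM
compound 3, `N=C(N)c1ccc2oc(-c3ccc(OCCCOc4ccccc4)cc3)cc2c1` — 7300 nM

All three were tested in an ADME assay on L6 cells (Rattus norvegicus) for cytotoxicity, read by resazurin assay, with a stated time of 70 h; on this read-out lower numbers stand for stronger inhibition and higher numbers for weaker inhibition. Compound 1 and compound 2 share a core and differ only in the length of the chain that links the two ends: phenoxymethyl in place of phenoxy on a saturated chain carbon, three bonds along the chain from an oxygen on an aromatic ring. That change gave a 2.6-fold lower number from compound 1 to compound 2 (0.42 log units; beyond the scatter). Compound 3 carries the same atoms as compound 1 joined differently; the difference between the two cores is not broken down here. In this assay compound 3 and compound 2 lie within the scatter of each other, while compound 3 stands apart from compound 1.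

Compound 4, `N=C(N)c1ccc2oc(-c3ccc(OCCCCOc4ccccc4)cc3)cc2c1`, has not yet been tested. It stands to compound 3 as compound 2 stands to compound 1: phenoxymethyl in place of phenoxy on a saturated chain carbon, three bonds along the chain from an oxygen on an aromatic ring. Among the compounds with values here, the lone earlier instance of this change, the step of a 2.6-fold lower number from compound 1 to compound 2 (0.42 log units; beyond the scatter), is the only guide, and it was made on the other core, so it is expected to carry over only roughly. The step from compound 3 to compound 4 is therefore estimated at a 2.1-fold lower number from compound 3 to compound 4 (0.32 log units; beyond the scatter). Compound 4 is expected to give about 3500 nM in this assay, most likely between 1400 nM and 9000 nM.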

Compound 4, half-maximal inhibitory concentration: 1300 nM
The estimate for compound 4 lay 2.7-fold (0.43 log units) above the measured number; measured number below the stated range.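

On the core of compound 3, the longer chain gave a 5.6-fold lower number from compound 3 to compound 4 (0.75 log units; beyond the scatter) in this assay, the same direction as the step seen on the core of compound 1. The two steps cannot be told apart in size: the same change on two cores in this assay, a 2.6-fold lower number (0.42 log units; beyond the scatter) from compound 1 to compound 2 and a 5.6-fold lower number (0.75 log units; beyond the scatter) from compound 3 to compound 4, 2.2-fold (0.33 log units) apart, within the scatter of two such steps. The change therefore carried over between these two cores as a lower number, and a gap of this size gives no sign that the core altered the step, but two pairs cannot show that the core has no influence at all, that the step would hold on a third core, or why the longer chain lowers the number.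

The compounds shown leave open whether the number keeps falling with a still longer chain, such as 2-phenoxyethyl or 3-phenoxypropyl in place of phenoxymethyl at this place. They also leave open what happens if the chain carries an amine or the phenoxy group is replaced by a carboxylic acid.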